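The compounds below may be only part of what the source reports. "The series", "measured", "known", "first", "only" and "open" are said of these compounds alone.

Compound 3 `N#CC1=C(N)Oc2c(c3nc4ccccc4nc3c3ccccc23)C12C(=O)N(Cc1cnnn1-c1ccc(N)cc1)c1ccccc12` gives in a functional assay on A549 cells (Homo sapiens) for antiproliferative activity, read by MTT assay, with a stated time of 48 h (on this read-out higher numbers stand for weaker inhibition and lower numbers for stronger inhibition), only a limit of the assay, > 50000 nM. Compound 1 `COc1ccc(-n2nncc2CN2C(=O)C3(C(C#N)=C(N)Oc4c3c3nc5ccccc5nc3c3ccccc43)c3ccccc32)cc1` likewise gives only a limit in this assay, > 50000 nM. Compound 2 `CCOc1ccc(-n2nncc2CN2C(=O)C3(C(C#N)=C(N)Oc4c3c3nc5ccccc5nc3c3ccccc43)c3ccccc32)cc1` gives 25200 nM in this assay. So on the numbers shown compound 3 sits at the limit of > 50000 nM in this assay, at which 2 of the 3 values shown sit, the weakest reading the assay can report. Compound 4 `Cc1ccc(-n2nncc2CN2C(=O)C3(C(C#N)=C(N)Oc4c3c3nc5ccccc5nc3c3ccccc43)c3ccccc32)cc1Cl` differs from it by 3-chloro-4-methylphenyl in place of 4-aminophenyl on an aromatic nitrogen. For the measured compounds named here, two measured steps touch that same ring: a step that the two limits leave unreadable from compound 1 to compound 3 and an at least 1.9-fold higher number from compound 2 to compound 3 (0.29 log units; that floor lies within the scatter); both are limited by the assay ceiling and neither shows a direction beyond the scatter. Compound 4 is therefore expected to stay close to that ceiling, with an expected step of an at least 1.2-fold lower number from compound 3 to compound 4 (0.09 log units; that floor lies within the scatter). The estimate for compound 4 is 40000 nM, in the range 12000 nM to 50000 nM.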

Compound 4, half-maximal inhibitory concentration: > 50000 nM
Compound 4 was reported as a limit; the forecaster's own chance of this, stated with the estimate: 55%; middle value at least 1.2-fold (0.09 log units) from the limit.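

In this assay compound 4 gives only a limit, > 50000 nM, so 3-chloro-4-methylphenyl on this aromatic nitrogen, with no hydrogen-bond donor, gives no readable value, just as 4-aminophenyl and 4-methoxyphenyl do, and the steps to compound 3 and compound 1 cannot be read. For the compounds shown here, the one readable step is an at least 1.9-fold higher number from compound 2 to compound 4 (0.29 log units; that floor lies within the scatter). Most of the series now rests at a single reading: the limit of > 50000 nM in this assay, at which 3 of the 4 values shown sit.

On these data alone, whether a longer chain on the oxygen, such as propoxy, would give a second readable value stays open. So does the effect of a carboxylic acid on this ring.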